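The source may hold more compounds than are shown below. What is called first, only, known or untested is meant among the compounds shown, and "the series" means these compounds.

Measured compounds:
Compound 1, `COC(=O)NCCOc1ccc(Cl)cc1C(=O)N[C@H](C(=O)Nc1ccc([N+](=O)[O-])cc1Cl)C(C)C`: in a functional assay on MCF7 cells (Homo sapiens) for inhibition, read by MTT assay, with a stated time of 72 h (on this read-out higher numbers stand for weaker inhibition and lower numbers for stronger inhibition), compound 1 gives > 10000 nM, which is a limit of the assay and not a number.
Compound 2, `CC(C)COC(=O)NCCOc1ccc(Cl)cc1C(=O)N[C@H](C(=O)Nc1ccc([N+](=O)[O-])cc1Cl)C(C)C`: in this assay compound 2 gives 10100 nM.
Compound 3, `C[C@H](NC(=O)c1cc(Cl)ccc1OCCNC(=O)OC(C)(C)C)C(=O)Nc1ccc([N+](=O)[O-])cc1Cl`: in this assay compound 3 gives > 10000 nM, again a limit of the assay and not a number.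

Compounds 1 and 2 share one core and differ in a single place: isopropyl in place of hydrogen on a saturated chain carbon bound to an oxygen next to a carbonyl group. The step that the limit leaves unreadable from compound 1 to compound 2 cannot be given a size because the limit of > 10000 nM in this assay, at which 2 of the 3 values shown sit, is where compound 1 sits; the value of compound 2 lies close to that limit.

Compound 3 is built on a different core than compound 1; the difference between the two cores is not broken down here. Compound 4, `CC(C)C[C@H](NC(=O)c1cc(Cl)ccc1OCCNC(=O)OC(C)(C)C)C(=O)Nc1ccc([N+](=O)[O-])cc1Cl`, has not yet been measured in this assay. It arises from compound 3 by the same kind of change that turns compound 1 into compound 2: isopropyl in place of hydrogen on a saturated chain carbon, two bonds along the chain from an amide-type nitrogen and a carbonyl carbon. The surroundings of the place are not the same, however. In compound 2 the isopropyl sits on a saturated chain carbon bound to an oxygen next to a carbonyl group, while in compound 4 it sits on a saturated chain carbon, two bonds along the chain from an amide-type nitrogen and a carbonyl carbon. It is thus the same kind of change, not the same change.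

The step that the limit leaves unreadable from compound 3 to compound 4 is expected to be small. This rests on compound 2, which after the same kind of change gives 10100 nM in this assay. For compound 4 the estimate is 15000 nM, expected to fall between 5000 nM and 50000 nM, with a limit rather than a number the more likely outcome.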

Compound 4, half-maximal inhibitory concentration: > 10000 nM
Compound 4: a limit, no number (the forecaster's own chance of this, stated with the estimate: 65%); the middle value lies beyond the limit too.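

In this assay compound 4 gives > 10000 nM as a limit of the assay and not a number. No size can be read for the change from compound 3 to compound 4, because both compounds sit at a limit: the limit of > 10000 nM in this assay, at which 3 of the 4 values shown sit. The compounds shown leave open whether isopropyl in place of hydrogen alters inhibition at all, on the core of compound 1 or on that of compound 3.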